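Changing the benzyl group of compound 1

The compounds below may be only part of what the source reports. "The series", "measured", "known", "first", "only" and "open" are said of these compounds alone.

compound 1 `COc1cc(CNCc2ccncc2)ccc1OCc1ccc(F)cc1` gives 6400 nM
compound 2 `COc1cc(CNCc2cccnc2)ccc1OCc1ccc(Cl)nc1` gives 5000 nM
compound 3 `COc1cc(CNCc2ccccn2)ccc1OCc1cccc(Cl)c1` gives 18000 nM

These numbers come from a functional assay on HeLa cells (Homo sapiens) for inhibition, with a stated time of 72 h; a higher number here means that more compound is needed for the effect, a lower number that less compound is needed. Compound 1 stands second highest of the three. Compound 2 lies within the scatter of it, while compound 3 needs clearly more compound. Compound 4 `COc1cc(CNCc2ccncc2)ccc1OCc1ccc(Cl)cc1Cl` has not yet been measured. It carries 2,4-dichlorophenyl in place of 4-fluorophenyl on a saturated chain carbon bound to an oxygen on an aromatic ring. Among the measured compounds shown here, no measured pair shows this change alone, and the three values give only a rough guide. In this assay the expected step of a 1.6-fold lower number from compound 1 to compound 4 (0.20 log units; within the scatter) is a small move towards a lower number, not beyond the scatter. The expected value for compound 4 is 4000 nM (estimated range 1500 nM to 11000 nM).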

Compound 4, half-maximal effective concentration: 3900 nM
The estimate for compound 4 lay 1.0-fold (0.01 log units) above the measured number; the range from low to high includes it.
By their numbers in this assay, from the lowest: compounds 4, 2 and 1 (each within the scatter of the next); then compound 3.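

Among the compounds shown here, compounds 1 and 4 form the first pair that differs in one place only: on a saturated chain carbon bound to an oxygen on an aromatic ring, 2,4-dichlorophenyl in place of 4-fluorophenyl gives a 1.6-fold lower number from compound 1 to compound 4 (0.22 log units; within the scatter) in this assay. At this position, then, two chlorine atoms instead of one fluorine leave the number within the usual scatter. Nothing measured here explains the size of this step. From the compounds shown here alone, whether an amine or a carboxylic acid on the phenyl ring, or a longer chain in place of the benzyl link, would shift the number beyond the scatter remains open.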